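Piperazine cap exchange: acetyl to methylsulfonyl, hepatocyte clearance

The source may hold more compounds than are shown below. What is called first, only, known or untested is meant among the compounds shown, and "the series" means these compounds.

Measured so far:
compound 1 `CN(C)[C@H]1CC[C@H](Nc2ncnc3[nH]cc(C4CCCO4)c23)CC1`: 59 uL/min; 36 uL/min (2 entries)
compound 2 `CC(=O)N1CCN([C@H]2CC[C@H](Nc3ncnc4[nH]cc(C5CCOCC5)c34)CC2)CC1`: 4.6 uL/min

In an ADME assay on cells (Hepatocyte, Rattus norvegicus) for metabolic stability (on this read-out higher numbers stand for fast clearance and lower numbers for slow clearance), compound 1 gives 59 uL/min; 36 uL/min (2 entries); the two entries of compound 1 the several entries of compound 1 in this assay, 59 uL/min; 36 uL/min (2 entries) lie within the usual scatter of repeat measurements. In this assay compound 2 gives 4.6 uL/min, the lowest number shown in the series, well apart from both entries of compound 1. A further entry for compound 2 exists without a single number attached.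

Compound 3 `CS(=O)(=O)N1CCN([C@H]2CC[C@H](Nc3ncnc4[nH]cc(C5CCOCC5)c34)CC2)CC1` is the next step. Its change from compound 2: methylsulfonyl in place of acetyl on an amine nitrogen in a ring. Among the compounds with values here, no measured pair carries this change, so no size of effect is known from the data.

The expected step from compound 2 to compound 3 is a 1.2-fold lower number from compound 2 to compound 3 (0.06 log units; within the scatter), none beyond the scatter. Compound 3 is estimated at 4 uL/min in this assay. The expected range for compound 3 runs from 2 uL/min to 9 uL/min.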

Compound 3, intrinsic clearance in a liver preparation (reported as CLH), per the amount of preparation that the assay uses: 16 uL/min
Compound 3: the middle estimate sits 4.0-fold (0.60 log units) below what was measured; measured number above the stated range.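

Within the data shown here, on an amine nitrogen in a ring, methylsulfonyl in place of acetyl is the first change that can be read as a single step. In this assay this exchange gives a 3.5-fold higher number from compound 2 to compound 3 (0.54 log units; beyond the scatter) and so shows that the cap on this nitrogen is not a silent position for clearance, with the acetyl cap carrying the lower number of the pair. The step rests on one number for each compound, and the only repeat numbers shown belong to another compound: the several entries of compound 1 in this assay, 59 uL/min; 36 uL/min (2 entries)

As far as these compounds go, what a different cap on the same nitrogen, such as a urea or a plain methyl group, would give remains open. Also open, from the compounds shown here alone, is whether the same exchange gives a step of this size with other groups on the core, since compound 1 differs from compound 2 in more than one place.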